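From chloro to diethylamino on compound 2

A few compounds are considered here, and "the series" means these few. Any claim that something is new, unique, unknown or untested is made for them only; others in the source may bear on it.

Of the compounds shown here, two have been measured so far in a functional assay on A-375 cells (Homo sapiens) for antiproliferative activity, read by trypan blue exclusion and crystal violet staining, with a stated time of 72 h (on this read-out lower numbers stand for stronger inhibition and higher numbers for weaker inhibition), and their numbers differ clearly. There compound 1 `CCCCOc1ccnc2c(O)c(CNC(=O)C3CCCCC3)ccc12` gives 540 nM while compound 2 `CCCC(=O)NC(c1ccc(Cl)cc1)c1cc(Cl)c2cccnc2c1O` gives 120 nM and so holds the lower of the two numbers, by a gap beyond the usual scatter. These two compounds differ in more than one place, so their gap cannot be tied to any single change. Compound 3 `CCCC(=O)NC(c1ccc(N(CC)CC)cc1)c1cc(Cl)c2cccnc2c1O` departs from compound 2 at one point: it has diethylamino in place of chloro on an aromatic carbon para to a large group. Among the compounds with values here, no measured pair shows such a change, so the expectation remains loose. A modest loss in this assay is expected rather than a large one, with an estimated 2.1-fold higher number from compound 2 to compound 3 (0.32 log units; beyond the scatter) as its size. Compound 3 is estimated at 250 nM with an expected range from 70 nM to 800 nM for its value.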

Compound 3, half-maximal inhibitory concentration: 130 nM
Estimate against measurement, compound 3: 1.9-fold (0.28 log units) above, within the range that was stated.
By their numbers in this assay, from the lowest: compounds 2 and 3 (each within the scatter of the next); then compound 1.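

In this assay, diethylamino in place of chloro on an aromatic carbon para to a large group gives a 1.1-fold higher number from compound 2 to compound 3 (0.03 log units; within the scatter) and so shows that this position accepts the change without a difference that can be told from the scatter. Within the data shown here, the 5 heavy atoms of diethylamino, with its hydrogen-bond acceptor, stand here in place of the single chlorine, and this is the first single-change reading at this place, though it rests on one pair alone. Nothing measured here accounts for how closely the two compounds agree.

From the compounds shown here alone, whether dimethylamino, a carboxylic acid or a morpholine ring on the same carbon would read like compound 3 remains open. Also open, going by these compounds, is whether this result would hold with a longer chain on the amide carbonyl.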